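Replacing methoxycarbonyl with trifluoromethyl in compound 2

The source may report more compounds than this note shows. Statements on the series, on what has been measured and on what is new or still open speak of the compounds shown alone.

Compound 1 `Cc1cc(/C=C/C#N)cc(C)c1Oc1cc(Nc2ccc(C#N)cc2)c(N)cc1C(N)=O` gives 0.63 ug/mL
Compound 2 `COC(=O)c1cc(N)c(Nc2ccc(C#N)cc2)cc1Oc1c(C)cc(/C=C/C#N)cc1C` gives 1.3 ug/mL

Both values come from a physicochemical assay for solubility, with a stated time of 4 h, at pH 7.4 (a lower number here means a less soluble compound, a higher number a more soluble compound), where compound 2 holds the higher number at 1.3 ug/mL. The next compound, compound 3 `Cc1cc(/C=C/C#N)cc(C)c1Oc1cc(Nc2ccc(C#N)cc2)c(N)cc1C(F)(F)F`, differs from it in one place: trifluoromethyl in place of methoxycarbonyl on an aromatic carbon. In short, this is trifluoromethyl in place of methoxycarbonyl on an aromatic carbon. Among the measured compounds shown here, only one measured step bears on this, the modest 2.1-fold higher number from compound 1 to compound 2 (0.31 log units; beyond the scatter). That step exchanges methoxy and amino on a carbonyl carbon, whereas here the whole methoxycarbonyl leaves, so it guides the expected size far better than the direction. A similarly modest change is therefore expected in this assay, tentatively downward, and the expected step is a 1.9-fold lower number from compound 2 to compound 3 (0.27 log units; within the scatter). The estimate for compound 3 is 0.7 ug/mL, with an expected range from 0.2 ug/mL to 2.5 ug/mL.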

Compound 3, solubility: 0.24 ug/mL
The estimate for compound 3 lay 2.9-fold (0.46 log units) above the measured number; the range from low to high includes it.
By their numbers in this assay, from the lowest: compound 3; then compound 1; then compound 2.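

At this aromatic carbon, para to a (4-cyanophenyl)amino group, the earlier step changed only what sat on the carbonyl carbon, whereas removing the whole methoxycarbonyl gives a larger change in this assay (a 5.4-fold lower number from compound 2 to compound 3 (0.73 log units; beyond the scatter)). Trifluoromethyl in place of carbamoyl at the same carbon moves the number the same way (a 2.6-fold lower number from compound 1 to compound 3 (0.42 log units; beyond the scatter)), so among these three compounds, trifluoromethyl gives the lowest number, below both carbonyl-bearing groups, with both steps beyond the scatter. Nothing available here accounts for this drop.

The compounds shown leave open whether the lower number follows the loss of the carbonyl or belongs to trifluoromethyl itself. They also leave open where a carboxylic acid or a dimethylamino group at this carbon would fall relative to compound 2 and compound 3 in this assay on this shared core.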